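Changing the Group on the Carbonyl Carbon: Expecting Compound 4

The source may report more compounds than this note shows. Statements on the series, on what has been measured and on what is new or still open speak of the compounds shown alone.

Of the compounds shown here, three built on a shared core have been measured in a functional assay on isolated protein for inhibition of Glucose-dependent insulinotropic receptor (Rattus norvegicus), read by HTRF and cAMP accumulation; on this read-out higher numbers stand for larger maximal responses and lower numbers for smaller maximal responses. Compound 1 `Cc1nc(S(C)(=O)=O)ccc1Oc1ncnc(OC2CCN(C(=O)SC3(C)CC3)CC2)c1F` gives 77%, compound 2 `Cc1nc(S(C)(=O)=O)ccc1Oc1ncnc(OC2CCN(C(=O)C(C)(F)F)CC2)c1F` gives 87%, and compound 3 `Cc1nc(S(C)(=O)=O)ccc1Oc1ncnc(OC2CCN(C(=O)C3CCCC3)CC2)c1F` gives 83%. Compound 3 thus holds the second highest of the three numbers; compound 2 lies nearest and compound 1 furthest, and the steps of a number 6 percentage points higher from compound 1 to compound 3 (within the scatter) and a number 4 percentage points lower from compound 2 to compound 3 (within the scatter) both stay within the scatter, as does a number 10 percentage points higher from compound 1 to compound 2 (within the scatter). Compound 4 `CCc1cnc(C(=O)N2CCC(Oc3ncnc(Oc4ccc(S(C)(=O)=O)nc4C)c3F)CC2)nc1` differs from compound 3 by 5-ethylpyrimidin-2-yl in place of cyclopentyl on a carbonyl carbon. Every measured step also changes the group on the carbonyl carbon, and none of them moves the response beyond the scatter, so no step beyond the scatter is expected in this assay here either. Compound 4 is therefore estimated at 84%, within 70% to 98%, corresponding to an expected a number 1 percentage points higher from compound 3 to compound 4 (within the scatter).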

Compound 4, largest response reached (reported as efficacy), in percent of the reference or control that the assay uses: 80%
Compound 4: middle estimate off by 4 percentage points, on the high side; the measured number falls inside the stated range.
By their numbers in this assay, from the lowest: compounds 1, 4, 3 and 2 (each within the scatter of the next).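

In this assay, 5-ethylpyrimidin-2-yl brings the first aromatic ring onto the carbonyl carbon, and the response stays within the scatter of all three earlier compounds (a number 3 percentage points lower from compound 3 to compound 4 (within the scatter)), (a number 7 percentage points lower from compound 2 to compound 4 (within the scatter)) and (a number 3 percentage points higher from compound 1 to compound 4 (within the scatter)). Among these four compounds, then, neither the aromatic ring nor its hydrogen-bond acceptors produce a step beyond the scatter at this position.

As far as these compounds go, whether an amine, a carboxylic acid or a longer chain on the carbonyl carbon would do so stays open, as does the contribution of the ethyl group on the pyrimidine. No measurement shown gives a reason for these steps.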